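This account rests on a few compounds, and the source may have more. Where it says the series, first, only, none or still open, it means among the compounds named here.

Measured so far:
Compound 1, `N#Cc1ccc(C(=O)NNc2c(Br)cccc2Br)cc1`: > 100000 nM
Compound 2, `CCOc1ccc(C(=O)NNc2c(F)cccc2F)cc1`: > 100000 nM

In a toxicity assay on MDCK cells (Canis lupus familiaris) for cytotoxicity, read by CCK-8 assay, with a stated time of 48 h (on this read-out lower numbers stand for higher toxicity in this test and higher numbers for lower toxicity in this test), compound 1 gives > 100000 nM, which is a limit of the assay rather than a number. Compound 2 also sits at its limit, with > 100000 nM. Compound 1 thus stands at the limit of > 100000 nM in this assay, at which 2 of the 2 values shown sit. The unmeasured compound 3, `Nc1ccc(C(=O)NNc2c(Br)cccc2Br)cc1`, differs from compound 1 by amino in place of cyano on an aromatic carbon. Among the compounds with values here, no measured pair shows what such a change does in this assay. The expected step is a number no higher from compound 1 to compound 3 (the limit leaves the size open), none beyond the usual scatter. Compound 3 is therefore estimated at 100000 nM, within a range from 50000 nM to 200000 nM, and most likely again reported only as a limit.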

Compound 3, half-maximal cytotoxic concentration: > 100000 nM
Compound 3: a limit, no number; the forecaster's own chance of this, stated with the estimate: 80%; the middle value lies on the limit itself.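

Within the data shown here, compound 1 and compound 3 both sit only at a limit of the assay, so swapping cyano for amino gives no step that can be read. The compounds shown leave open what any structural change does to toxicity in this assay, as none has a value that is an actual number.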